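Aryl Swap on the Guanidine Side Chain of Two Histamine Ligands

The compounds below may be only part of what the source reports. "The series", "measured", "known", "first", "only" and "open" are said of these compounds alone.

Measured so far:
Compound 1, `COc1ccc(C(C)NC(=O)/N=C(\N)NCCCc2sc(N)nc2C)cc1`, 37.2 nM
Compound 2, `Cc1nc(N)sc1CCCN/C(N)=N/C(=O)NC(C)c1ccco1`, 31.6 nM

Compound 2 holds the lowest of the two numbers in an assay on membranes from Sf9 cells for displacement of a labelled ligand from histamine H2 receptor (Homo sapiens), read by scintillation counting, with a stated time of 60 min (a lower number here means a stronger inhibitor, a higher number a weaker inhibitor), but its nearest neighbour, compound 1, sits within the scatter: a 1.2-fold lower number from compound 1 to compound 2 (0.07 log units; within the scatter). Compound 3, `Cc1nc(N)sc1CCCN/C(N)=N/C(=O)NC(C)c1ccc(F)cc1`, has not yet been measured in this assay. It differs from compound 2 in one place: 4-fluorophenyl in place of furan-2-yl on a saturated chain carbon bound to an amide-type nitrogen and a saturated chain carbon. Among the measured compounds shown here, the only measured step that bears on this change is the one from compound 1 to compound 2, where a 4-methoxyphenyl gave way to furan-2-yl and the number barely moved. Since two quite different aromatic groups at this position gave numbers within the scatter of each other, the 4-fluorophenyl of compound 3 is expected to behave alike, giving a 1.1-fold higher number from compound 2 to compound 3 (0.04 log units; within the scatter). Compound 3 is therefore estimated at 35 nM, with a range of 15 nM to 80 nM.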

Compound 3, inhibition constant: 31.6 nM
For compound 3 the middle estimate is 1.1-fold (0.04 log units) above the measured one; the measured number falls inside the stated range.
By their numbers in this assay, from the lowest: compounds 2, 3 and 1 (each within the scatter of the next).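

In this assay a third aromatic group on this saturated chain carbon again leaves the number within the scatter (no change at the digits printed from compound 2 to compound 3 (within the scatter)), so 4-fluorophenyl, with its six-membered ring of carbon only, cannot be told apart from furan-2-yl, with its five-membered ring holding one hetero atom. The compounds now also include a change on the ring itself (a 1.2-fold lower number from compound 1 to compound 3 (0.07 log units; within the scatter)), and fluoro in place of methoxy on an aromatic carbon likewise stays within the scatter. No evidence is available to explain these matching numbers.

From the compounds shown here alone, all three compounds carry an aromatic ring on this carbon, so it remains open how a saturated group such as cyclohexyl, or an amine on the ring, would read. Going by these compounds, whether the same insensitivity would hold with a longer chain on the core also remains open.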